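This account rests on a few compounds, and the source may have more. Where it says the series, first, only, none or still open, it means among the compounds named here.

For the measured compounds named here, in a functional assay on V79-379A cells (Cricetulus griseus) for cytotoxicity, read by MTT assay, in the presence of a further agent that is not named here (on this read-out higher numbers stand for weaker inhibition and lower numbers for stronger inhibition), compound 1 `COC1=CC(=O)c2c(c(CO)cn2C)C1=O` gives 240000 nM and compound 2 `COC1=CC(=O)c2c(c(COC(=O)c3ccccc3)cn2C)C1=O` gives 40 nM, the lower of the two numbers; the only step measured, a 6000-fold lower number from compound 1 to compound 2 (3.78 log units; beyond the scatter), concerns the benzoyl ester and not the aromatic carbon. Compound 3 `COC1=CC(=O)c2c(c(COC(=O)c3ccccc3)c(C3CC3)n2C)C1=O` differs from compound 2 by cyclopropyl in place of hydrogen on an aromatic carbon. Going by the values given here, no measured step bears on a substituent on this aromatic carbon, so no step beyond the scatter is expected in this assay, the estimate resting on compound 2 with 40 nM. Compound 3 is expected at 40 nM, within 10 nM to 200 nM, a step of no change at the digits printed from compound 2 to compound 3 (within the scatter).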

Compound 3, half-maximal inhibitory concentration: 1000 nM
For compound 3 the middle estimate is 25-fold (1.40 log units) below the measured one; measured number above the stated range.
By their numbers in this assay, from the lowest: compound 2; then compound 3; then compound 1.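

This aromatic carbon next to the ring nitrogen is the first site on the shared core shown to respond to a substituent other than at the benzoyl ester: in this assay, cyclopropyl in place of hydrogen gives a 25-fold higher number from compound 2 to compound 3 (1.40 log units; beyond the scatter). The benzoyl ester is present on both sides of this step, so the change on the aromatic carbon alone separates the two numbers. Nothing available accounts for the size of this step.

As far as these compounds go, whether methyl, an amine or a longer chain on this aromatic carbon would leave the number close to that of compound 2 remains open. Also open, from the compounds shown here alone, is whether cyclopropyl would have a comparable effect with the free hydroxyl of compound 1 in place of the benzoyl ester.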